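The source may report more compounds than this note shows. Statements on the series, on what has been measured and on what is new or still open speak of the compounds shown alone.

Measured so far in a functional assay on HT-29 cells (Homo sapiens) for antiproliferative activity, read by sulforhodamine B assay, with a stated time of 72 h; a lower number here means a stronger inhibitor, a higher number a weaker inhibitor:
- compound 1 `CCCCCCCCc1ccc(CCC(CO)(CO)NC(=O)CCCCC)c2ccccc12` gives 20300 nM
- compound 2 `CCCCCCCCc1ccc(CCC(CO)(CO)NC(=O)CCCCCCC)c2ccccc12` gives 22000 nM
- compound 3 `CCCCCCCCCC(=O)NC(CO)(CO)CCc1ccc(CCCCCCCC)c2ccccc12` has not yet been measured

Among the compounds with values here, compound 2, at 22000 nM, cannot be told apart from compound 1, the only other compound measured, as the two lie within the scatter of repeated measurements. Going on to compound 3 brings one structural change: ethyl in place of hydrogen on a saturated chain carbon, seven bonds along the chain from a carbonyl carbon. In words, this is ethyl in place of hydrogen on a saturated chain carbon, seven bonds along the chain from a carbonyl carbon. Within the data shown here, one measured step bears on it, the same exchange made five bonds along the chain: a 1.1-fold higher number from compound 1 to compound 2 (0.03 log units; within the scatter). That single step is thin evidence, but it gives no reason to expect a real shift in this assay in either direction. The expected step is a 1.1-fold higher number from compound 2 to compound 3 (0.04 log units; within the scatter), which stays within the scatter. For compound 3 the estimated value is 24000 nM, with an expected range from 12000 nM to 50000 nM.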

Compound 3, half-maximal inhibitory concentration: > 80000 nM
Compound 3: no number, only a limit (the forecaster's own chance of this, stated with the estimate: 15%); middle value at least 3.3-fold (0.52 log units) away from the limit.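

In this assay compound 3 gives no number, only a limit: the limit of > 80000 nM in this assay, at which 1 of the 3 values shown sits. Ethyl in place of hydrogen made no readable difference five bonds along the chain from the carbonyl carbon, but seven bonds along it gives an at least 3.6-fold higher number from compound 2 to compound 3 (0.56 log units; beyond the scatter), so in these compounds the effect of this exchange depends on where it is made. Butyl in place of hydrogen five bonds along gives the same picture, with an at least 3.9-fold higher number from compound 1 to compound 3 (0.59 log units; beyond the scatter), which shows that this chain can be lengthened only so far before the compound becomes a clearly weaker inhibitor.

As far as these compounds go, since compound 3 has only a limit, the true size of the loss stays unknown. From the compounds shown here alone, whether a longer chain, or an amine or a carboxylic acid on this chain, would bring the activity back remains open.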